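This account rests on a few compounds, and the source may have more. Where it says the series, first, only, none or still open, it means among the compounds named here.

Measured in a functional assay on MGC-803 cells (Homo sapiens) for cytotoxicity, read by MTT assay, with stated times of 48 h and 4 h; a lower number here means a stronger inhibitor, a higher number a weaker inhibitor:
- compound 1 `COc1ccc(/C=C/c2nc(NCCN(C)C)c3cc(Cl)ccc3n2)cc1OC`: 11800 nM
- compound 2 `COc1ccc(/C=C/c2nc(NCCN(C(C)C)C(C)C)c3cc(Cl)ccc3n2)cc1OC`: 15600 nM
- compound 3 `COc1ccc(/C=C/c2nc(NCCN3CCCCC3)c3cc(Cl)ccc3n2)cc1OC`: 13500 nM

Compound 2 stands level with the other two: a 1.3-fold higher number from compound 1 to compound 2 (0.12 log units; within the scatter), and a 1.2-fold lower number from compound 2 to compound 3 (0.06 log units; within the scatter). Compound 4 `CC(C)N(CCNc1nc(/C=C/c2ccc([N+](=O)[O-])cc2)nc2ccc(Cl)cc12)C(C)C` differs from it elsewhere: 4-nitrophenyl in place of 3,4-dimethoxyphenyl on a double-bonded chain carbon bound to a double-bonded chain carbon. This places 4-nitrophenyl in place of 3,4-dimethoxyphenyl on a double-bonded chain carbon bound to a double-bonded chain carbon. The measured steps, including a 1.1-fold higher number from compound 1 to compound 3 (0.06 log units; within the scatter), all change the group on the saturated chain, so none tests this exchange directly. They show only a flat series at that other site. No shift beyond the scatter is expected in this assay, and the estimated step is a 1.3-fold lower number from compound 2 to compound 4 (0.11 log units; within the scatter), with wide uncertainty. For compound 4 the expected value is 12000 nM, within an estimated range of 4000 nM to 35000 nM.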

Compound 4, half-maximal inhibitory concentration: 17300 nM
The estimate for compound 4 lay 1.4-fold (0.16 log units) below the measured number; measured number inside the range.
By their numbers in this assay, from the lowest: compounds 1, 3, 2 and 4 (each within the scatter of the next).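

In this assay, among the compounds shown here, the first exchange at this place, on a double-bonded chain carbon bound to a double-bonded chain carbon, gives a 1.1-fold higher number from compound 2 to compound 4 (0.04 log units; within the scatter) with 4-nitrophenyl in place of 3,4-dimethoxyphenyl. This site therefore joins the saturated chain in showing no shift beyond the scatter, so both sites varied in these compounds are flat. No measurement at hand bears on why this exchange leaves the number level.

Open, on these data alone, is whether a carboxylic acid or an unsubstituted phenyl at this place would move the number beyond the scatter. Also open, as far as these compounds go, is whether a longer saturated chain would do so.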